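The compounds below may be only part of what the source reports. "The series", "measured", "known", "first", "only" and "open" are said of these compounds alone.

Measured compounds in a functional assay on A549 cells (Homo sapiens) for cytotoxicity, read by MTT assay, with a stated time of 24 h; on this read-out lower numbers stand for stronger inhibition and higher numbers for weaker inhibition:
compound 1 `Cc1ccc2oc(-c3ccc(NC(=O)CN4CCN(CCCN(C)C)CC4)cc3)nc2c1` gives 10600 nM
compound 2 `Cc1ccc2oc(-c3ccc(NC(=O)CN4CCN(CCCN(C)C)CC4)c(C)c3)nc2c1` gives 15300 nM
compound 3 `Cc1cc(-c2nc3ccccc3o2)ccc1NC(=O)CCl` gives 33500 nM

Compound 3 stands highest of the three numbers in this assay; compound 2 is the nearest to it, compound 1 the furthest, and both gaps lie beyond the scatter. Compound 3 also differs from the other two in the whole chain on the amide, so its standing cannot be traced to a single change.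

Compound 4 `Cc1cc(-c2nc3cc(F)ccc3o2)ccc1NC(=O)CCl` is drawn from compound 3 by one change: fluoro in place of hydrogen on an aromatic carbon.

For the measured compounds named here, the only measured step that resembles it is the one where methyl replaced hydrogen on an aromatic carbon, a 1.4-fold higher number from compound 1 to compound 2 (0.16 log units; within the scatter), which stayed within the scatter. That step sits on a different ring and with a different group, so it bears on the present change only loosely. Going by the values given here, with no closer precedent, no step beyond the scatter is expected in this assay for compound 4, in either direction.

Compound 4 is therefore expected to give about 30000 nM in this assay, within 12000 nM to 75000 nM. The expected step is a 1.1-fold lower number from compound 3 to compound 4 (0.05 log units; within the scatter).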

Compound 4, half-maximal inhibitory concentration: 64500 nM
The estimate for compound 4 lay 2.2-fold (0.33 log units) below the measured number; the measured number falls inside the stated range.
By their numbers in this assay, from the lowest: compounds 1 and 2 (each within the scatter of the next); then compounds 3 and 4 (each within the scatter of the next).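

In this assay, the ring that carries the new fluoro, a six-membered aromatic ring of carbon only within a fused system of two rings, is now probed by a single change, giving a 1.9-fold higher number from compound 3 to compound 4 (0.28 log units; within the scatter). This step lies within the scatter, so fluoro in place of hydrogen at this place, meta to a fused ring and para to a fused ring, shows no readable effect on the number with the chloroacetamide chain in place; the earlier single change, a 1.4-fold higher number from compound 1 to compound 2 (0.16 log units; within the scatter), also lay within the scatter but sat on a different ring. No measurement at hand bears on why the number holds at this place.

As far as these compounds go, whether a chloro, methoxy or amine group at this place would give a step beyond the scatter remains open. Also open, from the compounds shown here alone, is whether fluoro would behave the same way on compound 2, with its longer amide chain.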